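Capping the Phenol: From Compound 3 to Compound 4

The source may hold more compounds than are shown below. What is called first, only, known or untested is meant among the compounds shown, and "the series" means these compounds.

Three measured compounds share one core. Compound 1 `N#Cc1c(-c2ccccc2)nc2c(c(-c3ccccc3)nn2-c2ccccc2)c1-c1ccc(O)cc1` carries a 4-hydroxyphenyl group, and in a functional assay on K562 cells (Homo sapiens) for antiproliferative activity, read by resazurin assay, with a stated time of 72 h (a lower number here means a stronger inhibitor, a higher number a weaker inhibitor), compound 1 gives 9600 nM. Compound 2 `COc1cc(-c2c(C#N)c(-c3ccco3)nc3c2c(-c2ccccc2)nn3-c2ccccc2)ccc1O` bears a 4-hydroxy-3-methoxyphenyl group and a furan-2-yl group, and in this assay compound 2 gives 24900 nM. Compound 3 `COc1cc(-c2c(C#N)c(-c3ccccc3)nc3c2c(-c2ccccc2)nn3-c2ccccc2)ccc1O` keeps the 4-hydroxy-3-methoxyphenyl group with phenyl in place of furan-2-yl. In this assay compound 3 reaches only a limit of the assay, > 50000 nM, so no number is known for it. The steps leading to it are an at least 5.2-fold higher number from compound 1 to compound 3 (0.71 log units; beyond the scatter) and an at least 2.0-fold higher number from compound 2 to compound 3 (0.30 log units; that floor lies within the scatter), the second resting on a floor that lies within the scatter. Compound 3 therefore stands at the limit of > 50000 nM in this assay, at which 1 of the 3 values shown sits.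

Compound 4 `COc1ccc(-c2c(C#N)c(-c3ccccc3)nc3c2c(-c2ccccc2)nn3-c2ccccc2)cc1OC` differs from compound 3 by methyl in place of hydrogen on an oxygen on an aromatic ring: hydroxy becomes methoxy, and the 4-hydroxy-3-methoxyphenyl group becomes 3,4-dimethoxyphenyl. Neither measured step touches this oxygen; both concern other places on the core. With compound 3 at the limit, the step will show only if compound 4 returns a number. Compound 4 is expected to remain at or near that limit, with a step that the limit leaves unreadable from compound 3 to compound 4 as the estimated step. The estimate for compound 4 in this assay is 60000 nM, within 20000 nM to 200000 nM.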

Compound 4, half-maximal inhibitory concentration: > 25000 nM
Compound 4 was reported as a limit; the forecaster's own chance of this, stated with the estimate: 70%; the middle value does not contradict the limit.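

Compound 4 reaches only a limit of the assay, > 25000 nM, in this assay. The step with methyl in place of hydrogen on this oxygen cannot be read, since compound 3 also stands at a limit: the limit of > 50000 nM in this assay, at which 1 of the 4 values shown sits.

Among the compounds shown here, the one readable step is an at least 2.6-fold higher number from compound 1 to compound 4 (0.41 log units; beyond the scatter), with 3,4-dimethoxyphenyl in place of 4-hydroxyphenyl, so compound 4 joins compound 3 on the weaker side of compound 1 whether this oxygen carries hydrogen or methyl.

On these data alone, whether the hydrogen on this oxygen matters at all remains open, for neither compound 3 nor compound 4 gives a number in this assay, and a comparison of the two would need a core on which both ends of the step stay measurable, such as that of compound 2 with its furan-2-yl group. Also open, as far as these compounds go, is what a longer chain on this oxygen would give, for example an ethyl group, or a chain ending in an amine or a carboxylic acid.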